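From 4-cyanophenyl to 3,4,5-trimethoxyphenyl on a shared core

The source may hold more compounds than are shown below. What is called first, only, known or untested is meant among the compounds shown, and "the series" means these compounds.

For the measured compounds named here, in a functional assay on HepG2 cells (Homo sapiens) for cytotoxicity, read by MTT assay, with a stated time of 24 h (on this read-out lower numbers stand for stronger inhibition and higher numbers for weaker inhibition), three related compounds have numbers so far. Compound 1 (`CC(=O)Nc1ccc(S(=O)(=O)N2C/C(=C\c3ccc(C#N)cc3)C(=O)/C(=C/c3ccc(C#N)cc3)C2)cc1`) gives 4880 nM as its reading, compound 2 (`COc1cc(/C=C2\CN(S(=O)(=O)c3ccc(F)cc3)C/C(=C\c3cc(OC)c(OC)c(OC)c3)C2=O)cc(OC)c1`) gives 3890 nM as its reading and compound 3 (`CC(=O)Nc1ccc(S(=O)(=O)N2C/C(=C\c3cccc([N+](=O)[O-])c3)C(=O)/C(=C/c3ccccc3F)C2)cc1`) gives 8800 nM as its reading. Compound 1 therefore stands within the usual scatter of both others. Compound 4 (`COc1cc(/C=C2\CN(S(=O)(=O)c3ccc(NC(C)=O)cc3)C/C(=C\c3ccc(C#N)cc3)C2=O)cc(OC)c1OC`) keeps the core of compound 1 and has one change: 3,4,5-trimethoxyphenyl in place of 4-cyanophenyl on a double-bonded chain carbon bound to a double-bonded ring carbon. Going by the values given here, no measured pair shows this swap on its own. Compound 2 also carries a 3,4,5-trimethoxyphenyl and gives 3890 nM as its reading, so no step beyond the scatter is expected in this assay and no firm direction can be argued. The estimated move is a 1.2-fold lower number from compound 1 to compound 4 (0.09 log units; within the scatter) and it is expected to stay small. For compound 4 the estimated value is 4000 nM with an expected range from 1800 nM to 9000 nM as its likely span.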

Compound 4, half-maximal inhibitory concentration: 2890 nM
Estimate against measurement, compound 4: 1.4-fold (0.14 log units) above; the range from low to high includes it.
By their numbers in this assay, from the lowest: compounds 4, 2, 1 and 3 (each within the scatter of the next, the first and the last beyond it).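

In this assay, for the compounds shown here, putting 3,4,5-trimethoxyphenyl in place of 4-cyanophenyl on a double-bonded chain carbon bound to a double-bonded ring carbon gives a 1.7-fold lower number from compound 1 to compound 4 (0.23 log units; within the scatter) as the first direct reading of this swap. The position therefore takes a group of 12 heavy atoms instead of 8 without a step beyond the scatter, so neither group can be ranked above the other here. No measurement of any property of these groups accompanies the result, and the step stands without an explanation.

Going by these compounds, whether a different kind of group at this place, such as an amine or a carboxylic acid, would move the number beyond the scatter remains open. On these data alone, it is also open whether the same swap would read alike on a different core.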